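The source may hold more compounds than are shown below. What is called first, only, known or untested is meant among the compounds shown, and "the series" means these compounds.

Compound 1 `O=C(CCCCC1CCSS1)Nc1ccc(OC(F)(F)F)cc1` and compound 3 `O=C(CCCCC(S)CCS)Nc1ccc(OC(F)(F)F)cc1` share one core, while compound 2 `O=C(CCCCC1CCSS1)Nc1cccc2ccccc12` and compound 4 `O=C(CCCCC(S)CCS)Nc1cccc2ccccc12` share another; the difference between the two cores is not broken down here. In a functional assay on KB cells (Homo sapiens) for inhibition, read by MTT assay, with a stated time of 24 h, tested at 0.1 ug/mL (a higher number here means more inhibition of growth at the concentration tested, a lower number less inhibition of growth), compound 1 gives 1.97% and compound 3 gives 7.27%. The structural change between them is a group of 5 heavy atoms (3 carbon, 2 sulfur; no ring) in place of a group of 5 heavy atoms (3 carbon, 2 sulfur; one five-membered non-aromatic ring with 2 hetero atoms), on a saturated chain carbon, four bonds along the chain from a carbonyl carbon, and the step it made, a number 5.3 percentage points higher from compound 1 to compound 3 (within the scatter), is within the scatter. For compound 2 this assay reports only "not active" (no number reported), with no number attached. Compound 4 stands to compound 2 as compound 3 stands to compound 1: the change is a group of 5 heavy atoms (3 carbon, 2 sulfur; no ring) in place of a group of 5 heavy atoms (3 carbon, 2 sulfur; one five-membered non-aromatic ring with 2 hetero atoms), on a saturated chain carbon, four bonds along the chain from a carbonyl carbon, at the same place on the chain, so it is the same change. Its earlier step, from compound 1 to compound 3, was small. Because compound 2 is recorded as "not active" (no number reported) and the step of a number 5.3 percentage points higher from compound 1 to compound 3 (within the scatter) did not rise beyond the scatter, compound 4 is expected to show little growth inhibition in this assay as well. The estimate for compound 4 in this assay is 4%, with a range from 0% to 15%.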

Compound 4, percent growth inhibition at one concentration: "not active" (no number reported)
Compound 4: no number reported; no gap can be computed for the estimate.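

Compound 2 and compound 4 are both recorded in this assay only as not active, with no number attached, and no new step can be read between them. Nothing measured here bears on this result. The compounds shown leave open whether the change from compound 2 to compound 4 alters growth inhibition by any amount.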